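Sulfonamide aryl variation on the coumarin enaminone series

This account rests on a few compounds, and the source may have more. Where it says the series, first, only, none or still open, it means among the compounds named here.

Measured so far in a functional assay on T47D cells (Homo sapiens) for cytotoxicity, read by sulforhodamine B assay, with a stated time of 48 h; on this read-out higher numbers stand for weaker inhibition and lower numbers for stronger inhibition:
compound 1 `O=C(/C=C\Nc1ccc(S(=O)(=O)Nc2ccccn2)cc1)c1cc2ccccc2oc1=O` gives 37600 nM;
compound 2 `Cc1cc(C)nc(NS(=O)(=O)c2ccc(N/C=C\C(=O)c3cc4ccccc4oc3=O)cc2)n1` gives 62200 nM;
compound 3 `Cc1cc(NS(=O)(=O)c2ccc(N/C=C\C(=O)c3cc4ccccc4oc3=O)cc2)nc(C)n1` gives 100000 nM.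

Compound 3 carries the highest of the three numbers in this assay; the gap to compound 2 is within the scatter, the gap to compound 1 is beyond it.

Compound 4 `O=C(/C=C\Nc1ccc(S(=O)(=O)Nc2cnc3ccccc3n2)cc1)c1cc2ccccc2oc1=O` differs from compound 3 by quinoxalin-2-yl in place of 2,6-dimethylpyrimidin-4-yl on a sulfonamide nitrogen. Among the measured compounds shown here, the steps that bear on this change are a 2.7-fold higher number from compound 1 to compound 3 (0.42 log units; beyond the scatter) and a 1.6-fold higher number from compound 2 to compound 3 (0.21 log units; within the scatter): both swaps of the aryl group on the sulfonamide nitrogen moved the number little. A step of similar size is therefore expected here, if anything back toward compound 1. The estimate for compound 4 in this assay is 60000 nM, range 25000 nM to 100000 nM, meaning a 1.7-fold lower number from compound 3 to compound 4 (0.22 log units; within the scatter).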

Compound 4, half-maximal inhibitory concentration: 86900 nM
Compound 4: the middle estimate sits 1.4-fold (0.16 log units) below what was measured; measured number inside the range.
By their numbers in this assay, from the lowest: compounds 1, 2, 4 and 3 (each within the scatter of the next, the first and the last beyond it).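

In this assay, quinoxalin-2-yl brings a six-membered aromatic ring of carbon only onto the sulfonamide nitrogen, yet the steps from both dimethylpyrimidine compounds stay within the scatter (a 1.2-fold lower number from compound 3 to compound 4 (0.06 log units; within the scatter); a 1.4-fold higher number from compound 2 to compound 4 (0.15 log units; within the scatter)). Against the pyridin-2-yl of compound 1, the step is modest but beyond the scatter (a 2.3-fold higher number from compound 1 to compound 4 (0.36 log units; beyond the scatter)). No measurement given here accounts for these steps.

From the compounds shown here alone, whether a saturated amine such as morpholine, or a carboxylic acid on the aryl group, would move the number remains open. So does whether changes to the shared core would move it further than changes at this nitrogen.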